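From Methyl to Ethyl on a Shared Core

The compounds below may be only part of what the source reports. "The series", "measured", "known", "first", "only" and "open" are said of these compounds alone.

Compound 1, `COC(=O)c1c(C)[n+]([O-])c2cc(C)c(C)cc2[n+]1[O-]`, was examined in an ADME assay on Vero cells (Chlorocebus sabaeus) for cytotoxicity; a lower number here means a stronger inhibitor, a higher number a weaker inhibitor. In this assay compound 1 gives > 62.5 ug/mL, and this is a limit of the assay, not a measured number. Compound 2, `COC(=O)c1c(C)[n+]([O-])c2ccc(C)cc2[n+]1[O-]`, gives > 62.5 ug/mL in this assay, which is likewise only a limit. The step that the two limits leave unreadable from compound 1 to compound 2 is therefore unreadable, because of the limit of > 62.5 ug/mL in this assay, at which 2 of the 3 values shown sit. Compound 3, `COC(=O)c1c(C)[n+]([O-])c2cc(F)c(F)cc2[n+]1[O-]`, carries fluorine in place of the methyl groups on the aromatic ring and gives 1.48 ug/mL in this assay, a measured number well inside the working range.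

Compound 4, `CCc1c(C(=O)OC)[n+]([O-])c2cc(C)c(C)cc2[n+]1[O-]`, has not yet been measured. Compared with compound 1, the change is methyl in place of hydrogen on a saturated chain carbon bound to an aromatic carbon. For the measured compounds named here, none of the measured steps touches this saturated chain, and the single measured step between compounds that differ in one place gives no readable size. The expectation for compound 4 can therefore rest only on where compound 1 itself stands, which is at the limit of the assay. On that basis compound 4 is expected to remain at or near that limit, with an estimate of 80 ug/mL and a range from 30 ug/mL to 200 ug/mL. The step that the limit leaves unreadable from compound 1 to compound 4 is thus expected to be small, with no direction that the data can support.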

Compound 4, half-maximal inhibitory concentration: > 62.5 ug/mL
Compound 4: a limit, no number (the forecaster's own chance of this, stated with the estimate: 70%); the middle value does not contradict the limit.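

Compound 1 and compound 4 both sit at a limit of this assay and not at a measured number, so no step between them can be read: the limit of > 62.5 ug/mL in this assay, at which 3 of the 4 values shown sit.

The compounds shown leave open whether going from methyl to ethyl on the shared core changes cytotoxicity at all, in either direction.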